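The compounds below may be only part of what the source reports. "The series", "measured", "known", "first", "only" and "open" are said of these compounds alone.

In an ADME assay on the whole organism (plasma) for pharmacokinetics, with Rattus norvegicus as the target (a lower number here means that the compound disappears faster, a higher number that the compound lasts longer), compound 1 `CC1(C)Oc2ccc(C#N)cc2[C@@H](/N=C(\NC#N)Nc2ccccc2)[C@@H]1O` gives 1.8 h as its half-life. For the measured compounds named here, compound 2 `CC1(C)Oc2ccc(C#N)cc2[C@@H](/N=C(\NC#N)Nc2ccc(Cl)cc2)[C@@H]1O` gives 7 h and so holds the higher of the two numbers measured so far. Compound 3 `CC1(C)Oc2ccc(C#N)cc2[C@@H](/N=C(\NC#N)Nc2ccc(F)cc2)[C@@H]1O` has not yet been measured. It differs from compound 2 by a single exchange (fluoro in place of chloro on an aromatic carbon), with fluoro in place of chloro on an aromatic carbon.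

Going by the values given here, only one measured step bears on this exchange. Among the compounds with values here, at the same aromatic carbon, chloro in place of hydrogen gave a 3.9-fold higher number from compound 1 to compound 2 (0.59 log units; beyond the scatter) and this modest step is the only guide available. Within the data shown here, no measured compound carries fluoro, so the data do not show whether it behaves more like hydrogen or more like chloro. Compound 3 is therefore expected to land somewhere between compound 1 at 1.8 h and compound 2 at 7 h on this scale. In this assay the expected step is a 1.9-fold lower number from compound 2 to compound 3 (0.29 log units; within the scatter) and so a move to a lower number, smaller than the measured one. For compound 3 the estimated half-life is 3.6 h with an expected range from 1.9 h to 7 h for now.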

Compound 3, half-life: 1.7 h
Compound 3: middle estimate off by 2.1-fold (0.33 log units), on the high side; measured number below the stated range.
By their numbers in this assay, from the lowest: compounds 3 and 1 (each within the scatter of the next); then compound 2.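

In this assay, the exchange of chloro for fluoro gives a 4.1-fold lower number from compound 2 to compound 3 (0.61 log units; beyond the scatter) and so removes the whole of the gain that chloro brought at this aromatic carbon. Fluoro in place of hydrogen gives a 1.1-fold lower number from compound 1 to compound 3 (0.02 log units; within the scatter) and thus cannot be told apart from hydrogen at this position, even though it is the halogen that stands closest in name to chloro. Among these three compounds, then, the longer half-life belongs to chloro specifically and not to halogens as a class, with compound 2 alone standing apart from the other two. Nothing at hand explains why chloro and fluoro part ways here.

The compounds shown leave open whether the longer half-life extends to other groups at this same carbon, such as bromo, methyl or methoxy, or whether chloro remains alone among them. They also leave open whether chloro would have a similar effect elsewhere on the ring, since every substituted compound here carries its halogen at the one place, para to a large group.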